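The source may report more compounds than this note shows. Statements on the series, on what has been measured and on what is new or still open speak of the compounds shown alone.

Of the compounds shown here, three have been measured so far and a fourth awaits measurement. Compound 1 `CC(=O)Nc1cccc(S(=O)(=O)Oc2ccccc2C(C)C)c1` gives 21000 nM in a functional assay on HT-1080 cells (Homo sapiens) for antiproliferative activity, read by sulforhodamine B assay, with a stated time of 48 h; on this read-out higher numbers stand for weaker inhibition and lower numbers for stronger inhibition. Going by the values given here, compound 2 `CC(C)c1ccccc1OS(=O)(=O)c1cccc(NC(=O)C(C)(C)C)c1` gives 11000 nM in this assay, and the only single-point step among the measured compounds is a 1.9-fold lower number from compound 1 to compound 2 (0.28 log units; within the scatter). Compound 3 `CC(=O)Nc1ccc(S(=O)(=O)Oc2ccccc2I)cc1` gives 17000 nM in this assay, the second highest of the three numbers, close to both compound 1 and compound 2. Compound 4 `O=C(CCCl)Nc1ccc(S(=O)(=O)Oc2ccccc2I)cc1` differs from compound 3 by chloromethyl in place of hydrogen on a saturated chain carbon bound to a carbonyl carbon. Among the compounds with values here, the one measured step bearing on a change at the acyl group is a 1.9-fold lower number from compound 1 to compound 2 (0.28 log units; within the scatter), which stayed within the scatter. For compound 4 the estimated step is therefore a 1.4-fold lower number from compound 3 to compound 4 (0.15 log units; within the scatter). Compound 4 is expected to give 12000 nM in this assay, within a range from 5000 nM to 30000 nM.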

Compound 4, half-maximal inhibitory concentration: 4200 nM
The estimate for compound 4 lay 2.9-fold (0.46 log units) above the measured number; measured number outside the range, below it.
By their numbers in this assay, from the lowest: compound 4; then compounds 2, 3 and 1 (each within the scatter of the next).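

In this assay, going from acetamido to ((2-chloroethyl)carbonyl)amino gives a 4.0-fold lower number from compound 3 to compound 4 (0.61 log units; beyond the scatter), so a change on the saturated chain carbon bound to a carbonyl carbon can move the number beyond the scatter. The earlier step at the acyl group, a 1.9-fold lower number from compound 1 to compound 2 (0.28 log units; within the scatter), had not shown this. Nothing available here explains the step.

The compounds shown leave open whether the chlorine or the longer chain carries the step; an ethyl or a 2-hydroxyethyl group here would separate the two. From the compounds shown here alone, whether 2-chloroethyl acts likewise on the core of compound 1 also remains open.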